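From methyl to methoxycarbonyl on compound 2

The compounds below may be only part of what the source reports. "The series", "measured", "known", "first", "only" and "open" are said of these compounds alone.

Among the measured compounds shown here, in an ADME assay on MT4 cells (Homo sapiens) for cytotoxicity (on this read-out lower numbers stand for higher toxicity in this test and higher numbers for lower toxicity in this test), compound 2 `Cc1cc(C)cc(S(=O)(=O)n2c(SCC(=O)Nc3ccc(C)cc3Cl)nc3ccccc32)c1` gives 5400 nM, the only exact number so far. Compound 1 `Cc1cc(C)cc(S(=O)(=O)n2c(SCC(=O)Nc3ccccc3[N+](=O)[O-])nc3ccccc32)c1` gives >= 26000 nM, which is a limit of the assay. Compound 3 `COC(=O)c1ccc(NC(=O)CSc2nc3ccccc3n2S(=O)(=O)c2cc(C)cc(C)c2)c(Cl)c1` has methoxycarbonyl in place of methyl on an aromatic carbon. For the measured compounds named here, one measured step bears on this change: an at least 4.8-fold lower number from compound 1 to compound 2 (0.68 log units; beyond the scatter). It also altered the group on the amide-type nitrogen, so changes there can move the number in this assay. Going by the values given here, with only that step as a guide, the expected change is small: a 1.7-fold higher number from compound 2 to compound 3 (0.22 log units; within the scatter). Compound 3 is estimated at 9000 nM, with an expected range of 3000 nM to 26000 nM.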

Compound 3, half-maximal cytotoxic concentration: 145000 nM
The estimate for compound 3 lay 16-fold (1.21 log units) below the measured number; the whole stated range lies below it.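

In this assay, compounds 1 and 2 differed across the whole group on the amide-type nitrogen, whereas this change touches one ring carbon, meta to a chloro group. That single swap gives a 27-fold higher number from compound 2 to compound 3 (1.43 log units; beyond the scatter), so this position alone can shift the number strongly towards lower toxicity in this test. Compound 1 stands at a limit, so its step to compound 3 cannot be read: the limit of >= 26000 nM in this assay, at which 1 of the 3 values shown sits.

From the compounds shown here alone, whether a carboxylic acid or an amine on this carbon would move the number the same way stays open. So does whether the effect depends on the chloro group.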